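Sulfonyl chain variants on the shared core

A few compounds are considered here, and "the series" means these few. Any claim that something is new, unique, unknown or untested is made for them only; others in the source may bear on it.

Compound 2 `Cn1c(-c2ccccc2C(F)(F)F)nnc1C12CCC(CCS(=O)(=O)C(C)(C)C)(CC1)CC2` stands at the assay limit in an assay on CHO-K1 cells for inhibition of 11-beta-hydroxysteroid dehydrogenase type 2 (Mus musculus), read by scintillation proximity assay; on this read-out higher numbers stand for weaker inhibition and lower numbers for stronger inhibition: compound 2 gives > 4000 nM, which is a limit and not a number. Compound 1 `CCSCCC12CCC(c3nnc(-c4ccccc4C(F)(F)F)n3C)(CC1)CC2` likewise gives > 4000 nM, a limit. Compound 3 `CCS(=O)(=O)CCC12CCC(c3nnc(-c4ccccc4C)n3C)(CC1)CC2` also gives only > 4000 nM, a limit. The single one-point step shown, a step that the two limits leave unreadable from compound 1 to compound 2, cannot be read because both of its ends sit at the limit of > 4000 nM in this assay, at which 3 of the 3 values shown sit. Compound 4 `CC(C)S(=O)(=O)CCC12CCC(c3nnc(-c4ccccc4C(F)(F)F)n3C)(CC1)CC2` differs from compound 2 by hydrogen in place of methyl on a saturated chain carbon bound to two saturated chain carbons and a sulfonyl sulfur. Within the data shown here, no readable measured step bears on this change; the only related change on this chain is unreadable. The expectation for compound 4 is a step that the limit leaves unreadable from compound 2 to compound 4 in this assay, most likely again reported as a limit. Compound 4 is estimated at 6000 nM, within 2000 nM to 20000 nM.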

Compound 4, half-maximal inhibitory concentration: > 4000 nM
Compound 4: no number, only a limit; the forecaster's own chance of this, stated with the estimate: 80%; the middle value does not contradict the limit.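

No new step can be read for compound 4 against compound 2 or compound 1, with both ends of each comparison at a limit: the limit of > 4000 nM in this assay, at which 4 of the 4 values shown sit.

The compounds shown leave open how these chain variants on the shared core rank in this assay.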